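From trifluoromethyl to cyano on a shared core

The source may report more compounds than this note shows. Statements on the series, on what has been measured and on what is new or still open speak of the compounds shown alone.

For the measured compounds named here, compound 3 (`O=C(Nc1ccc(C(F)(F)F)cc1)c1cc(Br)ccc1O`) gives 610 nM in a functional assay on KG-1 cells (Homo sapiens) for cytotoxicity, read by luminescence and CellTiter-Glo, with a stated time of 3 days (a higher number here means a weaker inhibitor, a lower number a stronger inhibitor), and holds the lowest of the three numbers so far. Compound 4 (`N#Cc1ccc(NC(=O)c2cc(Br)ccc2O)cc1`) carries cyano in place of trifluoromethyl on an aromatic carbon. Going by the values given here, no measured step covers this exchange. Two compounds with cyano stand higher, compound 1 (`N#Cc1ccc(NC(=O)c2cc(-c3ccncc3)ccc2O)cc1`) at 7990 nM and compound 2 (`N#Cc1ccc(NC(=O)c2cc(Cc3ccccc3)ccc2O)cc1`) at 1930 nM in the same test, but both also differ from compound 3 in a second place. Among the compounds with values here, the one measured step (a 4.1-fold lower number from compound 1 to compound 2 (0.62 log units; beyond the scatter)) concerns that other place and bears only indirectly. A small rise is therefore expected, an estimated 2.1-fold higher number from compound 3 to compound 4 (0.33 log units; beyond the scatter) in this assay on this thin evidence. Compound 4 is expected at an estimated 1300 nM with a range from 500 nM to 3500 nM as its likely span.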

Compound 4, half-maximal inhibitory concentration: 1290 nM
For compound 4 the middle estimate is 1.0-fold (0.00 log units) above the measured one, and the stated range covers the measured number.
By their numbers in this assay, from the lowest: compound 3; then compounds 4 and 2 (each within the scatter of the next); then compound 1.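

In this assay, cyano and trifluoromethyl can now be compared directly on the shared core, and the exchange moves the number modestly (a 2.1-fold higher number from compound 3 to compound 4 (0.33 log units; beyond the scatter)). With cyano held constant, the other varied place can also be read: bromo gives a lower number than pyridin-4-yl (a 6.2-fold lower number from compound 1 to compound 4 (0.79 log units; beyond the scatter)), while bromo and benzyl remain within the scatter (a 1.5-fold lower number from compound 2 to compound 4 (0.17 log units; within the scatter)). Nothing measured here explains these steps. Going by these compounds, an amine or a carboxylic acid in place of cyano remains open, as does whether the cyano step holds with benzyl or pyridin-4-yl in the other place.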